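This account rests on a few compounds, and the source may have more. Where it says the series, first, only, none or still open, it means among the compounds named here.

Measured in a functional assay on ECa-109 cells for inhibition, with ECa-109 cell line (Homo sapiens) as the target, read by sulforhodamine B assay; on this read-out lower numbers stand for stronger inhibition and higher numbers for weaker inhibition:
- Compound 1 `O=C1C(N2CCCCC2)=CC(=O)c2c1nc1n2[C@H]2OC[C@@H](O)[C@H]2OC1`: > 8000 nM (a limit)
- Compound 2 `COc1ccc(NC2=CC(=O)c3c(nc4n3[C@H]3OC[C@@H](O)[C@H]3OC4)C2=O)cc1`: 3410 nM
- Compound 3 `COc1cccc(NC2=CC(=O)c3c(nc4n3[C@H]3OC[C@@H](O)[C@H]3OC4)C2=O)c1`: 3340 nM

Compound 3 stands level with compound 2, as a 1.0-fold lower number from compound 2 to compound 3 (0.01 log units; within the scatter) lies within the scatter. The remaining result, for compound 1, is a limit.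

Compound 4 `CCCN(CCC)C1=CC(=O)c2c(nc3n2[C@H]2OC[C@@H](O)[C@H]2OC3)C1=O` carries dipropylamino in place of (3-methoxyphenyl)amino on a double-bonded ring carbon. The nearest evidence is an at least 2.3-fold lower number from compound 1 to compound 3 (0.37 log units; beyond the scatter), matched by an at least 2.3-fold lower number from compound 1 to compound 2 (0.37 log units; beyond the scatter), both modest and known only as bounds. Dipropylamino, like the piperidin-1-yl of compound 1, has no aromatic ring, so a modest move toward weaker inhibition is expected in this assay, and the result may reach the limit. The expected change is a 2.2-fold higher number from compound 3 to compound 4 (0.35 log units; beyond the scatter). For compound 4, the estimate is 7500 nM, with an expected range from 3500 nM to 16000 nM.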

Compound 4, half-maximal inhibitory concentration: > 16000 nM
Compound 4 gave a limit, no number; the forecaster's own chance of this, stated with the estimate: 50%; middle value at least 2.1-fold (0.32 log units) from the limit.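

In this assay, dipropylamino on this double-bonded ring carbon gives an at least 4.7-fold higher number from compound 3 to compound 4 (0.68 log units; beyond the scatter) and an at least 4.6-fold higher number from compound 2 to compound 4 (0.67 log units; beyond the scatter), so a second amine without an aromatic ring also falls short of both (methoxyphenyl)amino compounds. Compound 4 is known only as a limit: the limit of > 16000 nM in this assay, at which 1 of the 4 values shown sits. Compound 1 is also a limit, so the step between compound 1 and compound 4 cannot be read.

Still open, on these data alone, is whether the difference follows the aromatic ring or the amine hydrogen of the (methoxyphenyl)amino group. A propylamino group would keep that hydrogen without the ring, and a methyl(phenyl)amino group would keep the ring without the hydrogen.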